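The source may report more compounds than this note shows. Statements on the series, on what has been measured and on what is new or still open speak of the compounds shown alone.

In a functional assay on L1210 cells (Mus musculus) for inhibition (a lower number here means a stronger inhibitor, a higher number a weaker inhibitor), compound 1 `O=c1ccn(COCCO)c(=O)[nH]1` gives > 1000 ug/mL, which is a limit of the assay rather than a number. Compound 2 `Cc1cn(COCCO)c(=O)[nH]c1=O` likewise gives only the limit > 1000 ug/mL. Compound 3 `O=c1[nH]c(=O)n(COCCO)cc1/C=C/Br` also reaches no more than the limit > 1000 ug/mL. All three thus sit at one point, (the limit of > 1000 ug/mL in this assay, at which 3 of the 3 values shown sit), and so the steps a step that the two limits leave unreadable from compound 1 to compound 2, a step that the two limits leave unreadable from compound 1 to compound 3 and a step that the two limits leave unreadable from compound 2 to compound 3 cannot be read in size or direction. Compound 4 `CC(=O)OCCOCn1cc(/C=C/Br)c(=O)[nH]c1=O` differs from compound 3 by acetyl in place of hydrogen on an oxygen on a saturated carbon. No measured step bears on this change, and none of the shown steps has a readable size, so no direction beyond the scatter can be expected. Compound 4 is expected to give about 1000 ug/mL, between 300 ug/mL and 3000 ug/mL, an estimated step of a number no higher from compound 3 to compound 4 (the limit leaves the size open), most probably reported again as a limit only.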

Compound 4, concentration for 50% inhibition: > 1000 ug/mL
Compound 4 was reported as a limit (the forecaster's own chance of this, stated with the estimate: 80%); the middle value lies on the limit itself.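

Compound 3 and compound 4 both stop at a limit, so the step from hydrogen to acetyl cannot be read in size or direction: the limit of > 1000 ug/mL in this assay, at which 4 of the 4 values shown sit. The compounds shown leave open whether any change to the shared core gives a readable value in this assay at all.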